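Removing the Second Bromo in the Dibromo Hydrazone Series

This account rests on a few compounds, and the source may have more. Where it says the series, first, only, none or still open, it means among the compounds named here.

Measured so far in a functional assay on Caco-2 cells (Homo sapiens) for inhibition, read by MTT assay, with a stated time of 48 h; on this read-out lower numbers stand for stronger inhibition and higher numbers for weaker inhibition:
compound 1, `COc1cc(/C=N/Nc2nc(-c3ccc(Br)cc3)cs2)cc(Br)c1OC`, gives 36200 nM.
compound 2, `COc1cc(/C=N/Nc2nc(-c3ccc(C(F)(F)F)cc3)cs2)c(Br)c(Br)c1OC`, gives only the limit > 100000 nM.
compound 3, `COc1cc(/C=N/Nc2nc(-c3ccc(Br)cc3)cs2)c(Br)c(Br)c1OC`, gives only the limit > 100000 nM.

Compound 2 thus stands at the limit that two of the three values share (the limit of > 100000 nM in this assay, at which 2 of the 3 values shown sit), and no number is known for it. Compound 4, `COc1cc(/C=N/Nc2nc(-c3ccc(C(F)(F)F)cc3)cs2)cc(Br)c1OC`, differs from compound 2 by one change: hydrogen in place of bromo on an aromatic carbon. Going by the values given here, the one measured step that bears on this is the bromo-in-place-of-hydrogen change at the same place, which gave an at least 2.7-fold higher number from compound 1 to compound 3 (0.44 log units; beyond the scatter), a step beyond the scatter toward weaker inhibition. The step from compound 2 to compound 3 is a step that the two limits leave unreadable from compound 2 to compound 3 and tells nothing about the size here. Compound 4 makes the reverse of the change that carried compound 1 to compound 3, so the number is expected to move downward from the limit, toward the region where compound 1 sits, as an at least 2.0-fold lower number from compound 2 to compound 4 (0.30 log units; that floor lies within the scatter). For compound 4 the estimate in this assay is therefore 50000 nM, with a range from 20000 nM to 150000 nM.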

Compound 4, half-maximal inhibitory concentration: 65900 nM
Estimate against measurement, compound 4: 1.3-fold (0.12 log units) below, and the stated range covers the measured number.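

In this assay, going by these compounds alone, the bromo ortho to a bromo group and para to a methoxy group could now be followed on the trifluoromethyl side as well, where removing it gives a first real number with an at least 1.5-fold lower number from compound 2 to compound 4 (0.18 log units; that floor lies within the scatter), a floor that cannot by itself establish a change beyond the scatter. Within the data shown here, the bromo-in-place-of-hydrogen change can now be set side by side on two cores, though its size on the second remains bounded only from one side: the same change on two cores in this assay, an at least 2.7-fold higher number (0.44 log units; beyond the scatter) from compound 1 to compound 3 and an at least 1.5-fold higher number (0.18 log units; that floor lies within the scatter) from compound 4 to compound 2; the limit leaves it open whether they differ With this bromo absent, the comparison of the two groups on the far side of the molecule also becomes readable for the first time, and trifluoromethyl in place of bromo gives a 1.8-fold higher number from compound 1 to compound 4 (0.26 log units; within the scatter), so this pair does not tell the two groups apart.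

On these data alone, the values for compound 2 and compound 3 are both limits, so the step between them cannot be read and the full size of the effect of this bromo stays open: the limit of > 100000 nM in this assay, at which 2 of the 4 values shown sit. Also open is how a chloro group, a methyl group or an amine would read at this same place in this assay, compared with hydrogen and with bromo.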